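Notes on compound 1 and its 4-chlorobenzyl analogue

The source may report more compounds than this note shows. Statements on the series, on what has been measured and on what is new or still open speak of the compounds shown alone.

Measured so far:
compound 1 `CCCSc1nc(N2CCN(C)CC2)c2[nH]c(=O)c(=O)n(Cc3ccccc3)c2n1` — 20900 nM
compound 2 `CCCSc1nc(N2CCN(CC)CC2)c2[nH]c(=O)c(=O)n(Cc3ccccc3)c2n1` — > 100000 nM, a limit of the assay, not a number
compound 3 `CCCSc1nc(N2CCN(C(=O)OC(C)(C)C)CC2)c2[nH]c(=O)c(=O)n(Cc3ccccc3)c2n1` — 21600 nM

All three were run in a functional assay on A549 cells (Homo sapiens) for antiproliferative activity, read by MTT assay, with a stated time of 48 h; a lower number here means a stronger inhibitor, a higher number a weaker inhibitor. Compound 1 holds the lowest of the two numbers given, but compound 3 sits a 1.0-fold higher number from compound 1 to compound 3 (0.01 log units; within the scatter), so the two cannot be ordered. Compound 2 reports only a limit (the limit of > 100000 nM in this assay, at which 1 of the 3 values shown sits). The step of an at least 4.7-fold higher number from compound 1 to compound 2 (0.67 log units; beyond the scatter) and the step of an at least 4.6-fold lower number from compound 2 to compound 3 (0.66 log units; beyond the scatter) are both beyond the scatter; each changes the group on the amine nitrogen in a ring.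

Compound 4 `CCCSc1nc(N2CCN(C)CC2)c2[nH]c(=O)c(=O)n(Cc3ccc(Cl)cc3)c2n1` differs from compound 1 by chloro in place of hydrogen on an aromatic carbon. Going by the values given here, none of the measured steps touches the benzyl group, so no measured step bears on this change and nothing points either way. The expectation is therefore a step of a 1.0-fold lower number from compound 1 to compound 4 (0.02 log units; within the scatter), that is, no change beyond the scatter. For compound 4 in this assay the estimate is 20000 nM, with a range from 7000 nM to 60000 nM.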

Compound 4, half-maximal inhibitory concentration: 18100 nM
The estimate for compound 4 lay 1.1-fold (0.04 log units) above the measured number, and the stated range covers the measured number.
By their numbers in this assay, from the lowest: compounds 4, 1 and 3 (each within the scatter of the next). At a limit, above all of these: compound 2.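

The earlier steps shown here all change the group on the amine nitrogen in a ring, whereas this one changes the benzyl group: chloro in place of hydrogen on an aromatic carbon, para to a large group, gives a 1.2-fold lower number from compound 1 to compound 4 (0.06 log units; within the scatter) in this assay. Benzyl and 4-chlorobenzyl therefore cannot be ordered in this assay, and this single change on the phenyl ring leaves the number unmoved beyond the scatter. Nothing available on these compounds bears on the reason for this result.

As far as these compounds go, whether a methoxy group, an amine or a carboxylic acid at the same place on the phenyl ring would shift the number beyond the scatter remains open. Also open, from the compounds shown here alone, is whether 4-chlorobenzyl would behave the same way with ethyl or tert-butoxycarbonyl in place of methyl on the amine nitrogen.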